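One Inverted Stereocentre in a Growth Inhibition Pair

The source may hold more compounds than are shown below. What is called first, only, known or untested is meant among the compounds shown, and "the series" means these compounds.

Among the compounds with values here, in a functional assay on HCC 2998 cells (Homo sapiens) for inhibition, read by sulforhodamine B assay, with a stated time of 48 h (a higher number here means a weaker inhibitor of growth, a lower number a stronger inhibitor of growth), compound 2 `COc1ccc(C2([C@H]3C[C@H](n4cc(C)c(=O)[nH]c4=O)O[C@@H]3CO[Si](C)(C)C(C)(C)C)SCCCS2)cc1OC` gives 3310 nM as the only number available. For compound 1 `Cc1cn([C@H]2C[C@H](CC3=CC(=O)C(=O)C=C3)[C@@H](CO[Si](C)(C)C(C)(C)C)O2)c(=O)[nH]c1=O` the entry reads no result reported. Compound 3 `COc1ccc(C2([C@H]3C[C@@H](n4cc(C)c(=O)[nH]c4=O)O[C@@H]3CO[Si](C)(C)C(C)(C)C)SCCCS2)cc1OC` has the same atoms and bonds as compound 2 and differs only in configuration as drawn (the two compounds have the same atoms and bonds and differ only in configuration as drawn: 1 of 3 stereo elements differ; a stereocentre at a saturated ring carbon is drawn R in compound 2 and S in compound 3), with a stereocentre at a saturated ring carbon drawn R in compound 2 and S in compound 3. No measured step sizes such a change, so no shift beyond the scatter is expected in this assay in either direction. The estimated change is a 1.1-fold higher number from compound 2 to compound 3 (0.02 log units; within the scatter) and stays within that scatter. Compound 3 is expected at 3500 nM with an estimated range from 1300 nM to 9000 nM around it.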

Compound 3, concentration for 50% growth inhibition: 12900 nM
Beside the measured number, compound 3's estimate is 3.7-fold (0.57 log units) below it, outside the stated range (above it).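

Inverting the stereocentre at the saturated ring carbon from R to S gives a 3.9-fold higher number from compound 2 to compound 3 (0.59 log units; beyond the scatter) in this assay, so the S form is the weaker inhibitor of growth. Until this pair, no measured step had shown that this position responds to configuration at all. The shift can be assigned to that single stereocentre because of one structural fact: the fact that compounds 2 and 3 differ only in the configuration as drawn

This single pair cannot show whether the inversion would shift the number by a similar amount in other compounds. It also leaves open what happens when a free hydroxyl group or an amine replaces the silyl ether on the shared core.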